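Neopentyl for tert-butyl on a rearranged core

The source may report more compounds than this note shows. Statements on the series, on what has been measured and on what is new or still open speak of the compounds shown alone.

compound 1, `CC(C)(C)[C@@H](O)C(=O)N1C[C@@H]2C[C@@H]2[C@H]1C(=O)NCc1cc(Cl)ccc1-n1cnnn1`, 17 10^-6 cm/s
compound 2, `CC(C)(C)C[C@@H](O)C(=O)N1C[C@@H]2C[C@@H]2[C@H]1C(=O)NCc1cc(Cl)ccc1-n1cnnn1`, 25 10^-6 cm/s
compound 3, `CC(C)(C)[C@@H](O)C(=O)N1[C@H](C(=O)NCc2cc(Cl)ccc2-n2cnnn2)C[C@@H]2C[C@@H]21`, 16 10^-6 cm/s

In an ADME assay on Caco-2 cells (Homo sapiens) for permeability, read by LC-MS, in the apical to basolateral direction, with a stated time of 60 min, at pH 6.5 (a higher number here means that the compound crosses the layer faster, a lower number that the compound crosses the layer more slowly), compound 1 gives 17 10^-6 cm/s and compound 2 gives 25 10^-6 cm/s. Compound 2 differs from compound 1 by neopentyl in place of tert-butyl on a saturated chain carbon bound to a carbonyl carbon and an oxygen on a saturated carbon, and the measured step is a 1.5-fold higher number from compound 1 to compound 2 (0.17 log units; within the scatter). Compound 3 gives 16 10^-6 cm/s in this assay; its core and the core of compound 1 hold the same atoms joined differently, a difference that is not broken down here. Compound 4, `CC(C)(C)C[C@@H](O)C(=O)N1[C@H](C(=O)NCc2cc(Cl)ccc2-n2cnnn2)C[C@@H]2C[C@@H]21`, has not yet been measured. It differs from compound 3 by neopentyl in place of tert-butyl on a saturated chain carbon bound to a carbonyl carbon and an oxygen on a saturated carbon, the same change that was made earlier, occurring twice among these compounds. For compound 4 the expected step is a 1.4-fold higher number from compound 3 to compound 4 (0.16 log units; within the scatter), an expectation resting on the measured step of a 1.5-fold higher number from compound 1 to compound 2 (0.17 log units; within the scatter). Compound 4 is therefore estimated at 23 10^-6 cm/s, within a range from 13 10^-6 cm/s to 40 10^-6 cm/s.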

Compound 4, apparent permeability: 25 10^-6 cm/s
Compound 4: the middle estimate sits 1.1-fold (0.04 log units) below what was measured, within the range that was stated.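

In this assay, neopentyl in place of tert-butyl gives a 1.6-fold higher number from compound 3 to compound 4 (0.19 log units; within the scatter), and the step reads alike on the two cores: the same change on two cores in this assay, a 1.5-fold higher number (0.17 log units; within the scatter) from compound 1 to compound 2 and a 1.6-fold higher number (0.19 log units; within the scatter) from compound 3 to compound 4, 1.1-fold (0.03 log units) apart, within the scatter of two such steps. The change therefore carries over from the core of compound 1 to the core of compound 3 without a detectable difference between the two steps. Neither step stands clear of the scatter, however, so no effect of the change is established on either core, and two cores say nothing about a third.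

The compounds shown leave open what a longer chain, an amine or a carboxylic acid would give at this place. They also leave open whether the two cores would still read alike with such a group.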